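Chain Lengthening at the Ring Nitrogen: Propyl to Pentyl

A few compounds are considered here, and "the series" means these few. Any claim that something is new, unique, unknown or untested is made for them only; others in the source may bear on it.

Measured compounds:
compound 1, `C#CCCn1c(Cc2cc(OC)c(OC)c(OC)c2)nc2c(N)nc(F)nc21`, 25100 nM
compound 2, `CCCn1c(Cc2cc(OC)c(OC)c(OC)c2)nc2c(N)nc(F)nc21`, 25100 nM

In a functional assay on MCF7 cells (Homo sapiens) for antiproliferative activity (a higher number here means a weaker inhibitor, a lower number a stronger inhibitor), compound 1 gives 25100 nM. The step of no change at the digits printed from compound 1 to compound 2 (within the scatter). Compound 2 therefore stands level with compound 1 on the numbers shown, and in this assay compound 2 gives 25100 nM.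

Compound 3, `CCCCCn1c(Cc2cc(OC)c(OC)c(OC)c2)nc2c(N)nc(F)nc21`, is not yet measured. It differs from compound 2 as follows: ethyl in place of hydrogen on a saturated chain carbon, three bonds along the chain from an aromatic nitrogen

For the measured compounds named here, only one measured step bears on this change, no change at the digits printed from compound 1 to compound 2 (within the scatter), which altered the same chain without moving the number. Compound 3 is therefore expected to show a step of no change at the digits printed from compound 2 to compound 3 (within the scatter), none beyond the scatter. Compound 3 is estimated at 25100 nM, within 10000 nM to 63000 nM.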

Compound 3, half-maximal inhibitory concentration: 36300 nM
Compound 3: the middle estimate sits 1.4-fold (0.16 log units) below what was measured; low and high end bracket the measured number.
By their numbers in this assay, from the lowest: compounds 1, 2 and 3 (each within the scatter of the next).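

In this assay, extending the chain at this place from propyl to pentyl gives a 1.4-fold higher number from compound 2 to compound 3 (0.16 log units; within the scatter), so adding ethyl three bonds along the chain from an aromatic nitrogen does not move the number beyond the scatter. Setting this longer chain against the ethynyl-ended one gives a 1.4-fold higher number from compound 1 to compound 3 (0.16 log units; within the scatter), and all three chains therefore read alike. No measurement shown here accounts for these numbers. The compounds leave open whether a longer chain, or an amine or a carboxylic acid at the chain end, would shift the number beyond the scatter.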